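Swapping a bromo for trifluoromethyl on a fluorinated core

A few compounds are considered here, and "the series" means these few. Any claim that something is new, unique, unknown or untested is made for them only; others in the source may bear on it.

Of the compounds shown here, three built on one shared core have been measured so far, and a fourth awaits its result. Compound 1 `O=C(Nc1ccc(Oc2ccnc3[nH]ccc23)cc1)c1cc(-c2ccc(C(F)(F)F)cc2)ncn1` is the reference point; in a functional assay on PC-3 cells (Homo sapiens) for cytotoxicity, read by MTT assay, with a stated time of 72 h (a lower number here means a stronger inhibitor, a higher number a weaker inhibitor), compound 1 gives 2160 nM. Compound 2 `O=C(Nc1ccc(Oc2ccnc3[nH]ccc23)cc1)c1cc(-c2ccc(Br)cc2)ncn1` differs from it only in one change: bromo in place of trifluoromethyl on an aromatic carbon. Compound 2 gives 2610 nM, and the step of a 1.2-fold higher number from compound 1 to compound 2 (0.08 log units; within the scatter) is small. Compound 3 `O=C(Nc1ccc(Oc2ccnc3[nH]ccc23)c(F)c1)c1cc(-c2ccc(C(F)(F)F)cc2)ncn1` differs from compound 1 in a different way: fluoro in place of hydrogen on an aromatic carbon. In this assay compound 3 gives 4120 nM, so the step of a 1.9-fold higher number from compound 1 to compound 3 (0.28 log units; within the scatter) also stays within the usual spread of repeated measurements. All three numbers therefore sit close together, and none can be called stronger or weaker than another.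

Compound 4 `O=C(Nc1ccc(Oc2ccnc3[nH]ccc23)c(F)c1)c1cc(-c2ccc(Br)cc2)ncn1` has not yet been measured. It differs from compound 3 by bromo in place of trifluoromethyl on an aromatic carbon, which is the same change already seen between compound 1 and compound 2, made in the same place. The cores of compound 3 and compound 4 differ from those of compound 1 and compound 2 by fluoro in place of hydrogen on an aromatic carbon.

The step from compound 3 to compound 4 is expected to be a 1.2-fold higher number from compound 3 to compound 4 (0.08 log units; within the scatter), close to the earlier step, because a 1.2-fold higher number from compound 1 to compound 2 (0.08 log units; within the scatter) was small and the change is the same. Compound 4 is therefore estimated at 4900 nM in this assay. The expected range for compound 4 runs from 2500 nM to 10000 nM.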

Compound 4, half-maximal inhibitory concentration: 11300 nM
For compound 4 the middle estimate is 2.3-fold (0.36 log units) below the measured one, outside the stated range (above it).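

In this assay, putting bromo in place of trifluoromethyl on the core of compound 3 gives a 2.7-fold higher number from compound 3 to compound 4 (0.44 log units; beyond the scatter), a step beyond the scatter, while the same swap on the core of compound 1 stayed within it, yet the two steps cannot be told apart: the same change on two cores in this assay, a 1.2-fold higher number (0.08 log units; within the scatter) from compound 1 to compound 2 and a 2.7-fold higher number (0.44 log units; beyond the scatter) from compound 3 to compound 4, 2.3-fold (0.36 log units) apart, within the scatter of two such steps. Putting fluoro in place of hydrogen with the bromo group present gives a 4.3-fold higher number from compound 2 to compound 4 (0.64 log units; beyond the scatter), and this step also looks larger than its counterpart with trifluoromethyl, but again the gap is not a real difference: the same change on two cores in this assay, a 1.9-fold higher number (0.28 log units; within the scatter) from compound 1 to compound 3 and a 4.3-fold higher number (0.64 log units; beyond the scatter) from compound 2 to compound 4, 2.3-fold (0.36 log units) apart, within the scatter of two such steps. Going by these compounds alone, these four compounds therefore fit the idea that each change carries over from one core to the other with much the same effect, but with only one pair of steps per change, they neither prove this nor exclude a modest added effect when the two changes are combined.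

Going by these compounds, it remains open whether the same carry-over would hold for other groups in the place of the bromo, such as an amine or a carboxylic acid, or for a chloro in the place of the fluoro. On these data alone, all of these numbers also come from this assay, so whether the pattern extends to any other test stays unknown.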